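The source may report more compounds than this note shows. Statements on the series, on what has been measured and on what is new or still open speak of the compounds shown alone.

Working notes on the series

Two compounds of the series have a result in a functional assay on the whole organism (strain Wister albino) for inhibition, with Rattus norvegicus as the target, read by paw edema, with a stated time of 1 h, at a dose of 50 mg/kg by the intraperitoneal route; on this read-out lower numbers stand for less inhibition and higher numbers for more inhibition at the one dose given (going by the name of the read-out). Compound 1, `CN1C[C@@H](c2ccc(F)cc2)[C@@]2(Cc3ccccc3C2=O)[C@@]12C(=O)Nc1ccccc12`, carries a 4-fluorophenyl group on the shared core; in this assay compound 1 gives 40.6%. Compound 2, `CN1C(=O)[C@@]2(c3ccccc31)N(C)C[C@@H](c1ccco1)[C@@]21Cc2ccccc2C1=O`, carries a furan-2-yl group on a core that differs from compound 1 in more than one place; in this assay compound 2 gives 50.1%. Compound 2 has the higher of the two numbers, but its distance to compound 1 lies within the scatter of repeated measurements, so no order between the two can be read from these values.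

Compound 3, `CN1C(=O)[C@@]2(c3ccccc31)N(C)C[C@@H](c1ccc(F)cc1)[C@@]21Cc2ccccc2C1=O`, is the next compound to be measured. It follows from compound 2 by a single change: 4-fluorophenyl in place of furan-2-yl on a saturated ring carbon. Going by the values given here, no step between measured compounds covers this exchange directly. Compound 1 shows that the 4-fluorophenyl group, on a related core, gives 40.6% in this assay, which is within the scatter of the value of compound 2. The step of a number 5.1 percentage points lower from compound 2 to compound 3 (within the scatter) is therefore expected to be small, pointing slightly downward but not beyond the scatter. Compound 3 is estimated to give 45% in this assay, within a range of 33% to 57%.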

Compound 3, a percentage reported as inhibition, in the whole organism at one dose (the size of the read-out at that dose, not a potency): 52.9%
Estimate against measurement, compound 3: 7.9 percentage points below, and the stated range covers the measured number.
By their numbers in this assay, from the lowest: compounds 1, 2 and 3 (each within the scatter of the next, the first and the last beyond it).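

In this assay the exchange of furan-2-yl for 4-fluorophenyl on the saturated ring carbon gives a number 2.8 percentage points higher from compound 2 to compound 3 (within the scatter) and so separates neither group from the other on this core at this dose. With 4-fluorophenyl held in place, methyl in place of hydrogen on the amide-type nitrogen in a ring gives a number 12.3 percentage points higher from compound 1 to compound 3 (beyond the scatter) as the only step in the series beyond the scatter, modest in size, so among these three compounds a difference appears with the change at that nitrogen and not with the change at the ring carbon. Nothing at hand accounts for either step.

The compounds shown leave open whether the change at the nitrogen gives a similar step with furan-2-yl on the ring carbon, or with a longer chain such as ethyl or propyl on that nitrogen in place of methyl. Going by these compounds alone, they also leave open how an amine, a carboxylic acid or a simple alkyl chain would fare on the saturated ring carbon, since only two aromatic rings have been compared there.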